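Allyl for Phenyl on an Aromatic Nitrogen: Edema Inhibition

A few compounds are considered here, and "the series" means these few. Any claim that something is new, unique, unknown or untested is made for them only; others in the source may bear on it.

Compound 1 `C=CCn1c(SCC(=O)Nc2ccc(/C(C)=N/O)cc2)nnc1-c1ccccc1`: 71%
Compound 2 `C/C(=N\O)c1ccc(NC(=O)CSc2nnc(-c3ccccc3)n2-c2ccccc2)cc1`: 66%
Compound 3 `COc1cc(-c2nnc(SCC(=O)Nc3ccc(C(C)=O)cc3)n2-c2ccccc2)cc(OC)c1OC`: 63%

All three were measured in a functional assay on the whole organism (strain albino) for inhibition, with Rattus norvegicus as the target, read by paw edema, with stated times of 30 min and 5 h, at a dose of 0.28 mmol/kg by the oral route; on this read-out lower numbers stand for less inhibition and higher numbers for more inhibition at the one dose given (going by the name of the read-out). Compound 1 and compound 2 share a core and differ by allyl in place of phenyl on an aromatic nitrogen; this change made a number 5 percentage points higher from compound 2 to compound 1 (within the scatter). Compound 3 has another core; the difference between the two cores is not broken down here. Compound 4 `C=CCn1c(SCC(=O)Nc2ccc(C(C)=O)cc2)nnc1-c1cc(OC)c(OC)c(OC)c1` has not yet been measured. It arises from compound 3 by allyl in place of phenyl on an aromatic nitrogen, the same kind of change, the surroundings differing in that the ring atom beside the place bears a 3,4,5-trimethoxyphenyl group in compound 3 and compound 4 where it bears a phenyl group in compound 2 and compound 1. Compound 4 is expected to show a number 5 percentage points higher from compound 3 to compound 4 (within the scatter) in this assay, resting on compound 2 and compound 1, where a number 5 percentage points higher from compound 2 to compound 1 (within the scatter). Compound 4 is therefore estimated at 68%, between 56% and 80%.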

Compound 4, a percentage reported as inhibition, in the whole organism at one dose (the size of the read-out at that dose, not a potency): 64%
For compound 4 the middle estimate is 4 percentage points above the measured one; the measured number falls inside the stated range.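

In this assay, allyl in place of phenyl on an aromatic nitrogen made a number 1 percentage points higher from compound 3 to compound 4 (within the scatter), so the step on the core of compound 3 stays within the scatter. Set beside the earlier step, the two cores cannot be told apart: the same change on two cores in this assay, a number 5 percentage points higher (within the scatter) from compound 2 to compound 1 and a number 1 percentage points higher (within the scatter) from compound 3 to compound 4, 4 percentage points apart, within the scatter of two such steps. This shows only that no dependence on the core can be seen across these two pairs; it does not show that the change has no effect, nor that it would behave alike on any further core.

The compounds shown leave open how a methyl, a benzyl or a longer chain on that aromatic nitrogen would read. With one dose only, they also say nothing about potency.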